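Urea series on the shared core: step to compound 3

The source may hold more compounds than are shown below. What is called first, only, known or untested is meant among the compounds shown, and "the series" means these compounds.

Measured so far:
compound 1 `Cc1cc(NC(=O)NC2CCCCC2)ccc1N1CCC(N2CCCC2C)C1` — 11.2 nM
compound 2 `CC(=O)N1CCN(C(=O)Nc2ccc(N3CCC(N4CCCC4C)C3)c(C)c2)CC1` — 23 nM

In an assay on CHO cells for displacement of a labelled ligand from histamine receptor H3 (Macaca mulatta), read by scintillation counting, with a stated time of 1 h (on this read-out lower numbers stand for stronger inhibition and higher numbers for weaker inhibition), compound 2 gives the higher of the two numbers; a 2.1-fold higher number from compound 1 to compound 2 (0.31 log units; beyond the scatter). Compound 3 `Cc1cc(NC(=O)NCc2cc(Cl)cc(Cl)c2)ccc1N1CCC(N2CCCC2C)C1` returns to a secondary urea: (3,5-dichlorobenzyl)amino in place of 4-acetylpiperazin-1-yl on a carbonyl carbon. Within the data shown here, the only step bearing on this place is the one from compound 1 to compound 2, which moved the number by a modest amount beyond the scatter, so a reversal of roughly that size, toward a lower number, is expected in this assay. Compound 3 is therefore estimated at 12 nM, range 4 nM to 35 nM, a step of a 1.9-fold lower number from compound 2 to compound 3 (0.28 log units; within the scatter).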

Compound 3, inhibition constant: 28.8 nM
Compound 3: middle estimate off by 2.4-fold (0.38 log units), on the low side; measured number inside the range.
By their numbers in this assay, from the lowest: compound 1; then compounds 2 and 3 (each within the scatter of the next).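

In this assay the step of a 1.3-fold higher number from compound 2 to compound 3 (0.10 log units; within the scatter) shows that an aromatic (3,5-dichlorobenzyl)amino group and the non-aromatic 4-acetylpiperazin-1-yl group are not told apart on this carbonyl carbon. A return to a secondary urea does not by itself recover the number of compound 1: the change of cyclohexyl to 3,5-dichlorobenzyl on the amide-type nitrogen gives a 2.6-fold higher number from compound 1 to compound 3 (0.41 log units; beyond the scatter) and marks the first difference between two secondary ureas. No measurement at hand accounts for either step. Still open, going by these compounds, is whether an unsubstituted benzyl group would behave like compound 3, and whether an amine or a carboxylic acid on that nitrogen would move the number beyond the scatter.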